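A few compounds are considered here, and "the series" means these few. Any claim that something is new, unique, unknown or untested is made for them only; others in the source may bear on it.

In a functional assay on U-87MG ATCC cells (Homo sapiens) for cytotoxicity, with a stated time of 7 days (a higher number here means a weaker inhibitor, a lower number a stronger inhibitor), compound 1 `CC(C)=CCC/C(C)=C/CC/C(C)=C/CSc1ccccc1C(=O)OC(C)C` gives 52000 nM and compound 2 `CNC(=O)c1ccccc1SC/C=C(\C)CC/C=C(\C)CCC=C(C)C` gives 18000 nM as the two outer numbers. Compound 3 `CC(C)=CCC/C(C)=C/CC/C(C)=C/CSc1ccccc1C(=O)OCc1ccccc1` gives 30000 nM and sits within the scatter of both. Compound 4 `COCOC(=O)c1ccccc1SC/C=C(\C)CC/C=C(\C)CCC=C(C)C` is not yet measured and carries methoxy in place of phenyl on a saturated chain carbon bound to an oxygen next to a carbonyl group. Among the measured compounds shown here, the one measured change at that place, benzyl in place of isopropyl, gives a 1.7-fold lower number from compound 1 to compound 3 (0.24 log units; within the scatter) and stays within the scatter. The wider change of methylamino in place of isopropoxy gives a 2.9-fold lower number from compound 1 to compound 2 (0.46 log units; beyond the scatter) and is modest. No step beyond the scatter is therefore expected in this assay here. The expected step is a 1.1-fold higher number from compound 3 to compound 4 (0.04 log units; within the scatter) and carries no clear direction. For compound 4 the estimated value is 33000 nM with an expected range from 15000 nM to 70000 nM on current data.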

Compound 4, half-maximal inhibitory concentration: 10000 nM
Compound 4: middle estimate off by 3.3-fold (0.52 log units), on the high side, and the stated range ends above it.
By their numbers in this assay, from the lowest: compounds 4, 2, 3 and 1 (each within the scatter of the next, the first and the last beyond it).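

In this assay methoxy in place of phenyl gives a 3.0-fold lower number from compound 3 to compound 4 (0.48 log units; beyond the scatter) and so moves the number beyond the scatter at this place on the oxygen next to a carbonyl group, which benzyl in place of isopropyl did not do. Methoxymethyl in place of isopropyl gives a 5.2-fold lower number from compound 1 to compound 4 (0.72 log units; beyond the scatter) and widens the spread of the series, while methoxymethoxy in place of methylamino gives a 1.8-fold lower number from compound 2 to compound 4 (0.26 log units; within the scatter) and leaves compound 4 and compound 2 unseparated. No measurement shown accounts for these steps. Still open, on these data alone, is whether a free carboxylic acid or a longer chain such as ethoxymethyl at this place would read like compound 4.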